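The source may hold more compounds than are shown below. What is called first, only, known or untested is meant among the compounds shown, and "the series" means these compounds.

Compound 3 `O=C1O[C@H]([C@@H](O)Cn2cc(CNS(=O)(=O)c3ccc(F)cc3)nn2)C(OCc2ccccc2)=C1OCc1ccccc1` holds the middle place among the three compounds measured in a functional assay on HepG2 cells (Homo sapiens) for antiproliferative activity, read by MTT assay, with a stated time of 72 h; a lower number here means a stronger inhibitor, a higher number a weaker inhibitor. Compound 1 `O=C1O[C@H]([C@@H](O)Cn2cc(-c3ccc(Br)cc3)nn2)C(OCc2ccccc2)=C1OCc1ccccc1` gives 5070 nM in this assay, compound 2 `O=C1O[C@H]([C@@H](O)Cn2cc(-c3cccc(O)c3)nn2)C(OCc2ccccc2)=C1OCc1ccccc1` gives 62700 nM, and compound 3 gives 18300 nM. The two steps that reach compound 3 run in opposite directions: a 3.6-fold higher number from compound 1 to compound 3 (0.56 log units; beyond the scatter), while a 3.4-fold lower number from compound 2 to compound 3 (0.53 log units; beyond the scatter). Between compound 1 and compound 2 the gap is the largest of the set, a 12-fold higher number from compound 1 to compound 2 (1.09 log units; beyond the scatter).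

Compound 4 `CCCCCCCCCCc1cn(C[C@H](O)[C@H]2OC(=O)C(OCc3ccccc3)=C2OCc2ccccc2)nn1` differs from compound 3 by nonyl in place of ((4-fluorophenyl)sulfonyl)amino on a saturated chain carbon bound to an aromatic carbon. Among the measured compounds shown here, no measured step involves a plain chain in this place; the steps seen so far only swap one ring-bearing group for another, so none of them bears directly on this change. The two steps into compound 3 show that the departing group sits between the two aryl groups in this assay, which gives a reference point but no direction for the new chain. The step from compound 3 to compound 4 is therefore expected to be small, a 1.8-fold lower number from compound 3 to compound 4 (0.26 log units; within the scatter), with wide uncertainty. Compound 4 is estimated to give 10000 nM in this assay, within a range from 3000 nM to 40000 nM.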

Compound 4, half-maximal inhibitory concentration: 12200 nM
Compound 4: middle estimate off by 1.2-fold (0.09 log units), on the low side, within the range that was stated.
By their numbers in this assay, from the lowest: compound 1; then compounds 4 and 3 (each within the scatter of the next); then compound 2.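

In this assay, a plain chain with no ring and no hydrogen-bond donors or acceptors matches the group it replaces, a 1.5-fold lower number from compound 3 to compound 4 (0.18 log units; within the scatter), so in this pair neither the ring nor the hydrogen-bond donor and acceptors of ((4-fluorophenyl)sulfonyl)amino are required to keep this level of activity. Against the two aryl groups, decyl falls on opposite sides: a 5.1-fold lower number from compound 2 to compound 4 (0.71 log units; beyond the scatter), yet a 2.4-fold higher number from compound 1 to compound 4 (0.38 log units; beyond the scatter), so a ring on this aromatic carbon is not needed to improve on 3-hydroxyphenyl, while 4-bromophenyl still gives the lowest number of the set. No measured evidence is available to explain these differences.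

The compounds shown leave open how the number depends on chain length, which a shorter butyl or a longer dodecyl chain would test against decyl. They also leave open what an amine or a carboxylic acid at the end of the chain would do.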